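A few compounds are considered here, and "the series" means these few. Any claim that something is new, unique, unknown or untested is made for them only; others in the source may bear on it.

Three compounds have been tested in a functional assay on PC-3 cells (Homo sapiens) for cytotoxicity, read by MTT assay, with a stated time of 48 h; on this read-out higher numbers stand for weaker inhibition and lower numbers for stronger inhibition:

Compound 1 `CC1=NN(C(=O)c2ccc(C)cc2)C(c2ccccc2O)C1` gives 40600 nM in this assay.
Compound 2 `CCC(=O)N1N=C(C)CC1c1cc(Br)ccc1O` gives 37800 nM in this assay.
Compound 3 `Cc1ccc(C(=O)N2N=C(c3cc4ccccc4oc3=O)CC2c2ccccc2)cc1` gives 13200 nM in this assay.

Compound 3 has the lowest number of the three, and its gaps to compound 2 and to compound 1 both lie beyond the usual scatter, so it is the strongest inhibitor among them. Compound 4 `O=C(CN1CCC(O)CC1)N1N=C(c2cc3ccccc3oc2=O)CC1c1ccccc1` has not yet been measured. It differs from compound 3 by (4-hydroxypiperidin-1-yl)methyl in place of 4-methylphenyl on a carbonyl carbon. Among the compounds with values here, no measured pair shows this kind of change, so its effect is uncertain. The expected outcome is a step of a 1.1-fold higher number from compound 3 to compound 4 (0.06 log units; within the scatter) that stays within the scatter, in either direction. Compound 4 is therefore estimated at 15000 nM in this assay, within a range from 5000 nM to 50000 nM.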

Compound 4, half-maximal inhibitory concentration: "not active" (no number reported)
The entry for compound 4 holds no number; no gap can be computed for the estimate.
By their numbers in this assay, from the lowest: compound 3; then compounds 2 and 1 (each within the scatter of the next).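

Compound 4 is reported as "not active" with no number, so no step from compound 3 to compound 4 can be read, and nothing shown explains this result. From the compounds shown here alone, the size of the change from 4-methylphenyl to (4-hydroxypiperidin-1-yl)methyl in this assay stays open.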